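Cytotoxicity notes: aryl ketone variation in a triazolothiadiazine series

The source may hold more compounds than are shown below. What is called first, only, known or untested is meant among the compounds shown, and "the series" means these compounds.

Measured compounds so far:
compound 1 `COc1cc(-c2nnc3n2NC(c2cccs2)C(C(=O)c2ccccc2)S3)cc(OC)c1OC` — 69400 nM
compound 2 `COc1cc(-c2nnc3n2NC(c2cccs2)C(C(=O)c2ccc(F)cc2)S3)cc(OC)c1OC` — 45000 nM
compound 3 `COc1cc(-c2nnc3n2NC(c2ccco2)C(C(=O)c2ccco2)S3)cc(OC)c1OC` — 68700 nM

All three share one core and were tested in a functional assay on A549 cells (Homo sapiens) for cytotoxicity, read by MTT assay, with a stated time of 48 h; a lower number here means a stronger inhibitor, a higher number a weaker inhibitor. Compound 3 gives the second highest of the three numbers, with 68700 nM. Its nearest neighbour in value is compound 1 at 69400 nM, and the furthest is compound 2 at 45000 nM; both gaps lie within the scatter, so no order among the three can be stated.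

Compound 4 `COc1cc(-c2nnc3n2NC(c2ccco2)C(C(=O)c2cccs2)S3)cc(OC)c1OC` is not yet measured. It differs from compound 3 in one place: thiophen-2-yl in place of furan-2-yl on a carbonyl carbon.

For the measured compounds named here, the only step measured within this set is a 1.5-fold lower number from compound 1 to compound 2 (0.19 log units; within the scatter), a fluoro in place of hydrogen on an aromatic carbon, which is a different kind of change and does not bear directly on the swap at the carbonyl carbon. Going by the values given here, no pair differing only in the group on the carbonyl carbon has been measured. Among the compounds with values here, with every measured gap inside the scatter and no relevant precedent, no step beyond the scatter is expected in this assay in either direction.

Compound 4 is therefore estimated at 65000 nM, with a range from 35000 nM to 120000 nM. The expected step is a 1.1-fold lower number from compound 3 to compound 4 (0.02 log units; within the scatter).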

Compound 4, half-maximal inhibitory concentration: 78700 nM
For compound 4 the middle estimate is 1.2-fold (0.08 log units) below the measured one; the range from low to high includes it.
By their numbers in this assay, from the lowest: compounds 2, 3, 1 and 4 (each within the scatter of the next).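

For the compounds shown here, the pair of compound 3 and compound 4 gives the first direct reading at the carbonyl carbon, where a 1.1-fold higher number from compound 3 to compound 4 (0.06 log units; within the scatter) appears in this assay for thiophen-2-yl in place of furan-2-yl. Both groups are five-membered aromatic rings of equal heavy-atom count that differ in sulfur against oxygen, and this exchange on a carbonyl carbon leaves the number within the scatter, so the series gains no sign that this position distinguishes between the two rings in this assay. Nothing on hand offers an explanation for this reading, and no measurement beyond the cell assay bears on it.

Still open is whether a group of a different kind on the carbonyl carbon, such as an amine, a carboxylic acid or a longer alkyl chain, would carry the number beyond the scatter, since every compound shown holds an aromatic ring there. Also open, from the compounds shown here alone, is whether thiophen-2-yl in place of furan-2-yl on the carbonyl carbon reads the same when the rest of the molecule differs from compound 3.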